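The source may report more compounds than this note shows. Statements on the series, on what has been measured and on what is new or still open speak of the compounds shown alone.

- compound 1 `Nc1nc(-c2cc(N3C[C@H](O)[C@@H](O)C3)ccc2O)cc(C2CCCCCC2)n1`: 300 nM
- compound 2 `CN(C)c1cc(-c2cc(N3C[C@H](O)[C@@H](O)C3)ccc2O)nc(N)n1`: > 10000 nM (a limit, not a number)

Going by the values given here, in a functional assay on HCT-116 cells (Homo sapiens) for cytotoxicity, with a stated time of 48 h (on this read-out higher numbers stand for weaker inhibition of growth and lower numbers for stronger inhibition of growth), compound 1 gives 300 nM, the only actual number so far. Compound 3 `Nc1nc(-c2cc(N3C[C@H](O)[C@@H](O)C3)ccc2O)cc(C2CCNCC2)n1` has piperidin-4-yl in place of cycloheptyl on an aromatic carbon. Among the compounds with values here, one measured step bears on this change, where dimethylamino replaced cycloheptyl: an at least 33-fold higher number from compound 1 to compound 2 (1.52 log units; beyond the scatter). That step is large and beyond the scatter, but it is a single case with a different group. A higher number is therefore expected in this assay, meaning weaker inhibition of growth, though by a smaller step. The expected step is an 8.3-fold higher number from compound 1 to compound 3 (0.92 log units; beyond the scatter). For compound 3 the estimate is 2500 nM, with an expected range of 500 nM to 10000 nM.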

Compound 3, concentration for 50% growth inhibition: > 10000 nM
Compound 3: no number, only a limit (the forecaster's own chance of this, stated with the estimate: 25%); middle value at least 4.0-fold (0.60 log units) away from the limit.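

In this assay, piperidin-4-yl in place of cycloheptyl gives an at least 33-fold higher number from compound 1 to compound 3 (1.52 log units; beyond the scatter), so keeping a six-membered non-aromatic ring at this position does not preserve the growth inhibition of compound 1. Compound 2 and compound 3 cannot be ordered, and the step between them cannot be read. Both stand at a limit, not a number: the limit of > 10000 nM in this assay, at which 2 of the 3 values shown sit.

Still open, from the compounds shown here alone, is whether cyclohexyl, a six-membered ring of carbon only, would stay close to compound 1. That comparison would separate the effect of the smaller ring from that of the nitrogen in piperidin-4-yl.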